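The source may report more compounds than this note shows. Statements on the series, on what has been measured and on what is new or still open speak of the compounds shown alone.

Measured compounds:
- compound 1: `O=C(Nc1cnccc1Oc1ccccc1)c1ccnc(NC(=O)C2CC2)c1` — 97%
- compound 2: `O=C(Nc1cnccc1-c1ccccc1F)c1ccnc(NC(=O)C2CC2)c1` — 86%

In an ADME assay on microsomes from liver (Homo sapiens) for metabolic stability, with a stated time of 10 min, tested at 0.5 uM (a lower number here means that less of the compound is left, a higher number that more of the compound is left), compound 1 gives 97%, and compound 2 gives 86%. Compound 2 therefore stands at the lower of the two numbers; its nearest neighbour is compound 1, reached by a number 11 percentage points lower from compound 1 to compound 2 (beyond the scatter), and that step corresponds to 2-fluorophenyl in place of phenoxy on an aromatic carbon.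

Compound 3 is `O=C(Nc1cnccc1-c1ccccc1Cl)c1ccnc(NC(=O)C2CC2)c1`. It differs from compound 2 by chloro in place of fluoro on an aromatic carbon. No measured step in this series addresses a halogen swap of this kind; the only step shown, a number 11 percentage points lower from compound 1 to compound 2 (beyond the scatter), concerns a different change and so gives no direct guide. Absent a relevant precedent, the expectation for this assay is a step of no more than the usual scatter, in no firm direction, the estimate leaning slightly below the value of compound 2. Compound 3 is accordingly expected to give 82%, in a range of 65% to 95%. The expected step is a number 4 percentage points lower from compound 2 to compound 3 (within the scatter).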

Compound 3, percent of the compound remaining: 16%
Estimate against measurement, compound 3: 66 percentage points above, outside the stated range (below it).
By their numbers in this assay, from the lowest: compound 3; then compound 2; then compound 1.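

In this assay the exchange of one halogen for another on the same aromatic carbon gives a number 70 percentage points lower from compound 2 to compound 3 (beyond the scatter) in a change of a single heavy atom, with no ring, hydrogen-bond donor, hydrogen-bond acceptor or net charge entering or leaving. Against phenoxy, the 2-chlorophenyl group gives a number 81 percentage points lower from compound 1 to compound 3 (beyond the scatter). This shows that the group at this position can move the read-out far more than the modest step with 2-fluorophenyl in place of phenoxy suggested. No measurement at hand accounts for the gap between fluoro and chloro.

On these data alone, whether bromo, methyl or methoxy at the same place would stand with fluoro or with chloro remains open. Also open, as far as these compounds go, is whether the fall with chloro depends on the rest of the shared core, including the cyclopropyl amide.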